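Swapping the Hydroxyphenyl Ring for Thiophene

This account rests on a few compounds, and the source may have more. Where it says the series, first, only, none or still open, it means among the compounds named here.

Compound 1, `CC1=CC[C@H](C(C)(C)NC(=S)N/N=C/c2ccccc2)CC1`: 22200 nM
Compound 2, `CC1=CC[C@H](C(C)(C)NC(=S)N/N=C/c2ccc(O)cc2)CC1`: > 100000 nM (a limit)
Compound 3, `COc1cc(/C=N/NC(=S)NC(C)(C)[C@H]2CC=C(C)CC2)ccc1O`: < 700 nM (a limit)

In a functional assay on HT-29 cells (Homo sapiens) for inhibition, read by sulforhodamine B assay, with a stated time of 48 h (a higher number here means a weaker inhibitor of growth, a lower number a stronger inhibitor of growth), compound 1 gives 22200 nM. Compound 2 gives only > 100000 nM, which is a limit of the assay and not a number. Compound 3 likewise gives < 700 nM, again a limit. Among these three, compound 2 stands at the weak end. Compound 4, `CC1=CC[C@H](C(C)(C)NC(=S)N/N=C/c2cccs2)CC1`, carries thiophen-2-yl in place of 4-hydroxyphenyl on a carbon with a double bond to nitrogen. Among the measured compounds shown here, two measured steps bear on it: an at least 4.5-fold higher number from compound 1 to compound 2 (0.65 log units; beyond the scatter) and an at least 140-fold lower number from compound 2 to compound 3 (2.15 log units; beyond the scatter). The hydroxy that entered in the first of those steps leaves again here, and compound 4 has no donor in that position. Compound 4 is therefore expected to fall back toward the level of compound 1, a large step downward, an at least 5.0-fold lower number from compound 2 to compound 4 (0.69 log units; beyond the scatter). The estimate for compound 4 is 20000 nM, with a range from 5000 nM to 100000 nM.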

Compound 4, concentration for total growth inhibition: 57800 nM
For compound 4 the middle estimate is 2.9-fold (0.46 log units) below the measured one, within the range that was stated.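

In this assay, thiophen-2-yl in place of phenyl gives a 2.6-fold higher number from compound 1 to compound 4 (0.42 log units; beyond the scatter), so the ring in this place matters even when no hydroxy is involved. Thiophen-2-yl in place of 4-hydroxyphenyl gives an at least 1.7-fold lower number from compound 2 to compound 4 (0.23 log units; that floor lies within the scatter), and because that floor lies within the scatter, the true size of this step stays unknown. Compound 2 has only a limit, not a number: the limit of > 100000 nM in this assay, at which 1 of the 4 values shown sits.

As far as these compounds go, what a ring carrying an amine or a carboxylic acid would give in this place remains open. So does the effect of adding a methoxy group to the thiophene ring.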